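An added amino group on a weakly active compound

A few compounds are considered here, and "the series" means these few. Any claim that something is new, unique, unknown or untested is made for them only; others in the source may bear on it.

Compound 1 `CCOCn1c(N)c(C(N)=O)c2c(N)ncnc21`: > 100000 nM
Compound 2 `CCOCn1cc(C(=N)S)c2c(N)ncnc21`: 60000 nM
Compound 3 `CCOCn1c(N)c(C(=N)S)c2c(N)ncnc21`: not yet measured

The comparison rests on a functional assay on KB cells (Homo sapiens) for inhibition; on this read-out lower numbers stand for stronger inhibition and higher numbers for weaker inhibition. Among the compounds with values here, in this read-out, compound 2 gives 60000 nM as the only exact number so far. Compound 1 is reported as > 100000 nM and this value is a limit of the assay, not a number.

Compound 3 differs from compound 2 by one change, with amino in place of hydrogen on an aromatic carbon. Within the data shown here, no measured pair isolates this change, so the data give no direct guide to its effect. A shift beyond the usual scatter is therefore not expected in this assay, and no clear direction is predicted. The expected change is a 1.1-fold higher number from compound 2 to compound 3 (0.03 log units; within the scatter) as estimated here. For compound 3 the estimated value is 65000 nM with an expected range from 20000 nM to 100000 nM in this assay.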

Compound 3, half-maximal inhibitory concentration: > 320000 nM
Compound 3: no number, only a limit; the forecaster's own chance of this, stated with the estimate: 30%; at least 4.9-fold (0.69 log units) between middle value and limit.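

Within the data shown here, until now, no measured pair isolated this position, and the first such pair shows that, in this assay, amino in place of hydrogen on an aromatic carbon, next to the ring nitrogen, does not leave inhibition unchanged. The step is an at least 5.3-fold higher number from compound 2 to compound 3 (0.72 log units; beyond the scatter), so this change goes toward weaker inhibition, by more than the usual scatter. Compound 3 gives > 320000 nM, which is a limit of the assay and not a number. The step from compound 1 to compound 3 cannot be read because of two limits: the limit of > 100000 nM in this assay, at which 1 of the 3 values shown sits, and the limit of > 320000 nM in this assay, at which 1 of the 3 values shown sits.

From the compounds shown here alone, what a methyl group or a chlorine atom on the same aromatic carbon would do remains open. Going by these compounds, the true number for compound 3 also stays unknown.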